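Adding chloro to the quinazolin-4-yl part of compound 2

The source may hold more compounds than are shown below. What is called first, only, known or untested is meant among the compounds shown, and "the series" means these compounds.

Compound 1, `O=S(=O)(/C=C/c1ccccc1)Cc1ccc(Nc2ncnc3ccccc23)cc1`, gives in a functional assay on PC-3 cells (Homo sapiens) (on this read-out higher numbers stand for weaker inhibition of growth and lower numbers for stronger inhibition of growth), a value of > 100000 nM, which is a limit of the assay and not a number.
Compound 2, `O=S(=O)(/C=C/c1ccc(C(F)(F)F)cc1F)Cc1ccc(Nc2ncnc3ccccc23)cc1`, gives in this assay a value of 100000 nM.

Compound 2 thus stands with the only number shown in this assay; the one further value shown is a limit. Within the data shown here, the single measured step, a number no higher from compound 1 to compound 2 (the limit leaves the size open), concerns the group on a double-bonded chain carbon, and its size cannot be read, because one of its two values sits at the limit of > 100000 nM in this assay, at which 1 of the 2 values shown sits.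

Compound 3, `O=S(=O)(/C=C/c1ccc(C(F)(F)F)cc1F)Cc1ccc(Nc2ncnc3cc(Cl)ccc23)cc1`, differs from compound 2 only in that (chloro in place of hydrogen on an aromatic carbon). Among the measured compounds shown here, no measured step touches this part of the shared core, so none bears on the change, and the one step available gives no readable size to borrow. With nothing to indicate movement in either direction, the expectation for compound 3 in this assay is a step of no change at the digits printed from compound 2 to compound 3 (within the scatter), that is, no change beyond the scatter. Compound 3 is therefore estimated at 100000 nM, with a range from 30000 nM to 300000 nM, and it may well again be reported only as a limit.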

Compound 3, concentration for 50% growth inhibition: > 100000 nM
Compound 3: only a limit was reported (the forecaster's own chance of this, stated with the estimate: 50%); the middle value sits exactly at the limit.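

Compound 3 gives > 100000 nM in this assay, which is a limit of the assay and not a number. This is the first change shown on this part of the shared core, and the step to the 7-chloroquinazolin-4-yl group gives a number no lower from compound 2 to compound 3 (the limit leaves the size open), with no sign of stronger inhibition of growth. The size of this step, like that of the earlier one, cannot be read, because each has a value at the limit: the limit of > 100000 nM in this assay, at which 2 of the 3 values shown sit.

As far as these compounds go, whether an amine or a methoxy group would give a number clear of the limit remains open. Also open is whether chloro here has any effect at all, since the compounds shown give no starting point with a readable margin of growth inhibition.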